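Compound 3 gives up (benzylcarbamoyl)methyl for hydroxy

The compounds below may be only part of what the source reports. "The series", "measured", "known", "first", "only" and "open" are said of these compounds alone.

compound 1 `CN1C(=O)N(Cc2nc3ccccc3n2CCCCO)c2ccccc2S1(=O)=O`: 219000 nM
compound 2 `CC(C)CCn1c(CN2C(=O)C(CC(=O)O)c3ccccc32)nc2ccccc21`: 16500 nM
compound 3 `CC(C)CCn1c(CN2C(=O)C(CC(=O)NCc3ccccc3)c3ccccc32)nc2ccccc21`: 720 nM

In an ADME assay on HEp-2 cells (Homo sapiens) for cytotoxicity (a lower number here means that less compound is tolerated, a higher number that more compound is tolerated), compound 3 gives 720 nM and so holds the lowest of the three numbers, clearly under both compound 2 and compound 1. The next compound, compound 4 `CC(C)CCn1c(CN2C(=O)C(O)c3ccccc32)nc2ccccc21`, has not yet been measured. Its difference from compound 3 is hydroxy in place of (benzylcarbamoyl)methyl on a saturated ring carbon in a single place: hydroxy in place of (benzylcarbamoyl)methyl on a saturated ring carbon.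

Among the compounds with values here, only one measured step bears on this change. It is a 23-fold lower number from compound 2 to compound 3 (1.36 log units; beyond the scatter) and is large, with benzylamino in place of hydroxy on a carbonyl carbon. Compound 4 also lacks the benzylamino part, so that step, read in reverse, points to a higher number. Within the data shown here, the match is only partial, since no measured compound carries hydroxy on this ring carbon. Compound 1 has a different core and offers little guidance here. The expected change is a 35-fold higher number from compound 3 to compound 4 (1.54 log units; beyond the scatter) towards a higher number, a large step beyond the scatter. Compound 2, also without the benzylamino part, stands at 16500 nM in this assay as the nearest guide. Compound 4 is therefore expected at 25000 nM (estimated range 6000 nM to 100000 nM).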

Compound 4, half-maximal cytotoxic concentration: 3310 nM
Compound 4: the middle estimate sits 7.6-fold (0.88 log units) above what was measured; measured number outside the range, below it.
By their numbers in this assay, from the lowest: compound 3; then compound 4; then compound 2; then compound 1.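

Hydroxy on the saturated ring carbon gives a result the earlier compounds could not show, since until now only the end of the side chain had changed, not the whole group on that carbon. In this assay, removing the full (benzylcarbamoyl)methyl group gives a 4.6-fold higher number from compound 3 to compound 4 (0.66 log units; beyond the scatter), yet hydroxy in place of carboxymethyl gives a 5.0-fold lower number from compound 2 to compound 4 (0.70 log units; beyond the scatter), so compound 4 sits between the two side-chain compounds, and the group with the fewest heavy atoms does not give the highest number of the three. The read-out at this position therefore does not simply follow the size of the group among these three compounds, and no measurement offered here explains the order.

The compounds shown leave open whether an amine or a methoxy group on this ring carbon would fall near compound 4, and whether a longer chain ending in a carboxylic acid would raise the number further than carboxymethyl does. They also leave open how much of the low number of compound 3 belongs to the benzyl part, which a simple methyl amide would separate from the amide itself.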